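Hydrazone series: bromophenyl for hydroxyphenyl, cytotoxicity read-out

This account rests on a few compounds, and the source may have more. Where it says the series, first, only, none or still open, it means among the compounds named here.

Three members of the series have been run in an ADME assay on HEL cells (Homo sapiens) for cytotoxicity; a higher number here means that more compound is tolerated, a lower number that less compound is tolerated. Compound 1 `O=C(COc1cccc2ccccc12)N/N=C/c1ccc(Br)cc1` stays at a limit of the assay, > 100 ug/mL, so no number is given for it. Compound 2 `O=C(COc1cccc2ccccc12)N/N=C/c1ccccc1O` gives 20 ug/mL. Compound 3 `C/C(=N\NC(=O)COc1cccc2ccccc12)c1ccccc1O` gives 20 ug/mL, level with compound 2 at the digits shown and within the scatter. How the cores of compound 3 and compound 2 differ is not broken down here.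

The measured step is an at least 5.0-fold higher number from compound 2 to compound 1 (0.69 log units; beyond the scatter), the change being (4-bromophenyl in place of 2-hydroxyphenyl on a carbon with a double bond to nitrogen). Its end point is a limit, (the limit of > 100 ug/mL in this assay, at which 1 of the 3 values shown sits), so the true size of the step is open.

Compound 4 `C/C(=N\NC(=O)COc1cccc2ccccc12)c1ccc(Br)cc1` is not yet measured. The change from compound 3 is 4-bromophenyl in place of 2-hydroxyphenyl on a carbon with a double bond to nitrogen. It is the same kind of change as from compound 2 to compound 1, though the carbon carrying the group has a saturated chain carbon as a further neighbour here and only the double-bonded nitrogen there. Since compound 3 sits at the same value as compound 2, the step to compound 4 is expected to be a 5.0-fold higher number from compound 3 to compound 4 (0.70 log units; beyond the scatter), resting on the measured step from compound 2 to compound 1. Compound 4 is expected to give 100 ug/mL, probably again at the limit of this assay.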

Compound 4, minimum cytotoxic concentration in the HEL assay: 20 ug/mL
Compound 4: middle estimate off by 5.0-fold (0.70 log units), on the high side; the measured number lies below the stated range.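

In the HEL assay the new step reads no change at the digits printed from compound 3 to compound 4 (within the scatter), so the change does not carry over unchanged from the core of compound 1 to the core of compound 4: the same change on two cores in the HEL assay, an at least 5.0-fold higher number (0.69 log units; beyond the scatter) from compound 2 to compound 1 and no change at the digits printed (within the scatter) from compound 3 to compound 4, at least 5.0-fold (0.69 log units) apart, beyond the scatter of two such steps

In a physicochemical assay for lipophilicity, measured as octanol-water partition (a lower number here means a more polar compound, a higher number a more lipophilic compound), compound 3 gives 3.08 and compound 4 gives 3.61, the step being a number 0.53 log units higher from compound 3 to compound 4 (beyond the scatter), so on this core the partition coefficient moves while the read-out on HEL cells stays level.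

The two pairs do not show which feature of the cores separates the steps, and the true size of the step on the core of compound 1 stays open: the limit of > 100 ug/mL in the HEL assay, at which 1 of the 4 values shown sits.

As far as these compounds go, whether the two cores also part for a group such as an amine or a carboxylic acid in place of 4-bromophenyl remains open. Also open, from the compounds shown here alone, is how a longer chain in place of the saturated chain carbon on the carbon with a double bond to nitrogen would affect the step.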